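Difluorophenyl replacement in a series at the assay limit

The source may hold more compounds than are shown below. What is called first, only, known or untested is meant among the compounds shown, and "the series" means these compounds.

Compound 1 `Cc1nnsc1CO/N=C/c1c(C)nn(C)c1Oc1cccc(F)c1` — > 50000 nM
Compound 2 `Cc1cccc(Oc2c(/C=N/OCc3snnc3C)c(C)nn2C)c1` — > 50000 nM

In a functional assay on PANC-1 cells (Homo sapiens) for inhibition, read by MTT assay, with a stated time of 48 h (a higher number here means a weaker inhibitor, a lower number a stronger inhibitor), compound 1 gives only a limit of the assay, > 50000 nM. Compound 2 likewise gives only a limit in this assay, > 50000 nM. For the measured compounds named here, the one measured step, a step that the two limits leave unreadable from compound 1 to compound 2, therefore cannot be read, as both ends sit at the same limit; the only evidence on hand is the limit of > 50000 nM in this assay, at which 2 of the 2 values shown sit.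

Compound 2 thus stands at the limit of this assay, with nothing to rank it against compound 1.

Compound 3 `Cc1nnsc1CO/N=C/c1c(C)nn(C)c1Oc1cccc(F)c1F` has not yet been measured. It differs from compound 2 by 2,3-difluorophenyl in place of 3-methylphenyl on an oxygen on an aromatic ring. Going by the values given here, no measured step bears on this change, and the one step that exists is unreadable, so no direction can be taken from the measured pairs. Both measured compounds sit at the limit, and compound 3 is expected to behave in the same way. Compound 3 is therefore estimated at 50000 nM, with a range from 20000 nM to 100000 nM. The expected step of a number no higher from compound 2 to compound 3 (the limit leaves the size open) is estimated as none beyond the scatter, with a limit again the most likely outcome.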

Compound 3, half-maximal inhibitory concentration: 12200 nM
Compound 3: middle estimate off by 4.1-fold (0.61 log units), on the high side, and the stated range ends above it.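

In this assay, compound 3 is the only one of the three to give a measured number rather than a limit, which shows that the aromatic ring on the oxygen can change the read-out in this series: the limit of > 50000 nM in this assay, at which 2 of the 3 values shown sit.

The change from 3-methylphenyl to 2,3-difluorophenyl gives an at least 4.0-fold lower number from compound 2 to compound 3 (0.61 log units; beyond the scatter), and fluoro in place of hydrogen on an aromatic carbon gives an at least 4.0-fold lower number from compound 1 to compound 3 (0.61 log units; beyond the scatter), so this single replacement on the ring of compound 1 is enough to bring the series within the measurable range. Compound 1 and compound 2 each stand at a limit, so both steps give only the smallest possible size of the change, and their true sizes cannot be read.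

The compounds shown leave open whether the added fluoro is specifically required, since they do not show whether chloro, methoxy or an amine on the same aromatic carbon would give a similar step. They also leave open how the shared core and the methyl-bearing side chain contribute, and whether replacing that chain with a longer one or adding a carboxylic acid would change the number for compound 3.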